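Methyl to trifluoromethyl on the pendant aryl of compound 1

The source may hold more compounds than are shown below. What is called first, only, known or untested is meant among the compounds shown, and "the series" means these compounds.

Measured so far in a functional assay on DLD-1 cells (Homo sapiens) for antiproliferative activity, read by CellTiter-Glo, with a stated time of 72 h; a higher number here means a weaker inhibitor, a lower number a stronger inhibitor:
compound 1, `Cc1ccc(-c2ccccc2S(=O)(=O)N2CCC(N3CCC(C)CC3)CC2)cc1`, gives 366 nM
compound 2, `Cc1cccc(S(=O)(=O)N2CCC(N3CCC(C)CC3)CC2)c1`, gives 25 nM

Compound 1 stands at the highest of the two numbers; compound 2 gives the lower one, and the gap between them lies beyond the usual scatter. Compound 3, `CC1CCN(C2CCN(S(=O)(=O)c3ccccc3-c3ccc(C(F)(F)F)cc3)CC2)CC1`, differs from compound 1 by trifluoromethyl in place of methyl on an aromatic carbon. Among the compounds with values here, no pair among the measured compounds carries this change, so nothing here tells its direction. The step of a 1.1-fold higher number from compound 1 to compound 3 (0.04 log units; within the scatter) is expected to stay within the scatter. Compound 3 is estimated at 400 nM, with a range from 120 nM to 1500 nM.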

Compound 3, half-maximal inhibitory concentration: 122 nM
The estimate for compound 3 lay 3.3-fold (0.52 log units) above the measured number; the range from low to high includes it.
By their numbers in this assay, from the lowest: compound 2; then compound 3; then compound 1.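

In this assay trifluoromethyl in place of methyl gives a 3.0-fold lower number from compound 1 to compound 3 (0.48 log units; beyond the scatter) as a modest step, so the aromatic carbon para to a large group responds to what it carries. Compound 1 alone could not show this sensitivity, and a larger group at this carbon is tolerated here, with the number falling rather than rising. Nothing measured here bears on why the step occurs. From the compounds shown here alone, whether an amine, a carboxylic acid or a methoxy group at this carbon would lower the number further remains open. So does whether the same change holds on other compounds of the series.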